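A few compounds are considered here, and "the series" means these few. Any claim that something is new, unique, unknown or untested is made for them only; others in the source may bear on it.

Compound 1 `O=S(=O)(c1ccccc1F)c1cn(C2CCNC2)c2ncccc12` gives 2 nM in an assay on HeLa cells for displacement of a labelled ligand from 5-hydroxytryptamine receptor 6 (Homo sapiens); on this read-out lower numbers stand for stronger inhibition and higher numbers for weaker inhibition. Going by the values given here, only one other number is known: compound 2 `O=S(=O)(c1cccc(Br)c1)c1cn(C2CCNC2)c2ncccc12` gives 1.3 nM in this assay, and the step of a 1.5-fold lower number from compound 1 to compound 2 (0.19 log units; within the scatter) means the two sit within the scatter of one another. That step concerns the aryl on the sulfonyl sulfur and says nothing about the ring on the aromatic nitrogen. Compound 3 `O=S(=O)(c1ccccc1F)c1cn(C2CCCNC2)c2ncccc12` differs from compound 1 by piperidin-3-yl in place of pyrrolidin-3-yl on an aromatic nitrogen. Among the compounds with values here, no measured step bears on this change. The expectation for compound 3 is thus a step of a 1.5-fold higher number from compound 1 to compound 3 (0.18 log units; within the scatter) not beyond the scatter, with widened uncertainty. Compound 3 is estimated at 3 nM, range 1 nM to 10 nM.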

Compound 3, inhibition constant: 2 nM
Compound 3: middle estimate off by 1.5-fold (0.18 log units), on the high side, within the range that was stated.
By their numbers in this assay, from the lowest: compounds 2, 1 and 3 (each within the scatter of the next).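

In this assay, going by these compounds alone, the swap at the aromatic nitrogen gives no change at the digits printed from compound 1 to compound 3 (within the scatter) with the 2-fluorophenyl on the sulfonyl sulfur kept, the first reading at this position. So far, piperidin-3-yl and pyrrolidin-3-yl cannot be told apart here. Nothing on hand explains this result. Still open, on these data alone, is whether piperidin-3-yl behaves the same alongside 3-bromophenyl on the sulfonyl sulfur. Also open, as far as these compounds go, is what an open-chain amine such as aminoethyl, or cyclopentyl with no ring nitrogen, would give on the aromatic nitrogen.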